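This account rests on a few compounds, and the source may have more. Where it says the series, first, only, none or still open, it means among the compounds named here.

Going by the values given here, compound 3 `CCCCCOC(=O)N1CCN(C(=O)c2nc(Nc3cc(C4CC4)[nH]n3)c3cc(Cl)ccc3n2)C[C@H]1C` carries a pentyl group on an oxygen next to a carbonyl group and is one of three compounds measured in an assay for inhibition of serine/threonine-protein kinase PAK 4 (Homo sapiens), read by FRET and Z'-LYTE, with a stated time of 60 min, tested at 50 uM, in the presence of a further agent that is not named here (a higher number here means a stronger effect of the compound at the concentration tested, a lower number a weaker effect), where compound 3 gives 32.7%. Among the three numbers this is the lowest, but its nearest neighbour, compound 2 `C[C@@H]1CN(C(=O)c2nc(Nc3cc(C4CC4)[nH]n3)c3cc(Cl)ccc3n2)CCN1C(=O)OC(C)(C)C` with a tert-butyl group at that position, gives 36.4%, and the step of a number 3.7 percentage points lower from compound 2 to compound 3 (within the scatter) lies within the scatter, so the two cannot be ranked against each other. Compound 1 `CC(C)C(=O)OCOC(=O)N1CCN(C(=O)c2nc(Nc3cc(C4CC4)[nH]n3)c3cc(Cl)ccc3n2)C[C@H]1C`, which bears a longer ((isopropylcarbonyl)oxy)methyl group there, gives 86.9%, and the steps of a number 50.5 percentage points lower from compound 1 to compound 2 (beyond the scatter) and a number 54.2 percentage points lower from compound 1 to compound 3 (beyond the scatter) are both large.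

Compound 4 `CC(C)OC(=O)N1CCN(C(=O)c2nc(Nc3cc(C4CC4)[nH]n3)c3cc(Cl)ccc3n2)C[C@H]1C` differs from compound 3 in one place: isopropyl in place of pentyl on an oxygen next to a carbonyl group. The step that bears most directly on this change is the swap of one plain alkyl group for another, a number 3.7 percentage points lower from compound 2 to compound 3 (within the scatter), which stayed within the scatter. The two large steps from compound 1 both remove a group of a different kind, so they say little about a pentyl-to-isopropyl change. On that basis a step of no size beyond the scatter is expected, a number 2.3 percentage points higher from compound 3 to compound 4 (within the scatter). Compound 4 is therefore estimated to give 35% in this assay, within a range from 20% to 52%.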

Compound 4, a percentage reported as inhibition, at one concentration (the size of the read-out at that concentration, not a potency): 91.2%
The estimate for compound 4 lay 56.2 percentage points below the measured number; the whole stated range lies below it.
By their numbers in this assay, from the lowest: compounds 3 and 2 (each within the scatter of the next); then compounds 1 and 4 (each within the scatter of the next).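

The pentyl-to-isopropyl change on an oxygen next to a carbonyl group, read in this assay, gives the largest step in this set, a number 58.5 percentage points higher from compound 3 to compound 4 (beyond the scatter), so a swap between two plain alkyl groups can matter here as much as the loss of the ((isopropylcarbonyl)oxy)methyl group. The change from tert-butyl to isopropyl, which removes only one methyl, gives a number 54.8 percentage points higher from compound 2 to compound 4 (beyond the scatter), so this position separates closely related alkyl groups, and the order does not simply follow group size: isopropyl, with its 3 carbons, stands well above both the larger pentyl and tert-butyl. The earlier compounds shown here left the ((isopropylcarbonyl)oxy)methyl group alone at the high end, but a number 4.3 percentage points higher from compound 1 to compound 4 (within the scatter) shows that isopropyl cannot be ranked against it, so a high number here does not depend on that longer group.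

The compounds shown leave open whether the high number is particular to isopropyl or also holds for ethyl, butyl or cyclopropyl at this place. No measurement shown here accounts for these steps.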